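Swapping a benzyl for a direct aryl on the core

A few compounds are considered here, and "the series" means these few. Any claim that something is new, unique, unknown or untested is made for them only; others in the source may bear on it.

Of the compounds shown here, two sharing one core have been tested in an ADME assay on HepG2 cells (Homo sapiens) for cytotoxicity, read by luminescence, CellTiter-Glo and ATP content, with a stated time of 72 h; a higher number here means that more compound is needed for the effect, a lower number that less compound is needed. Compound 1 `COc1ccc(F)cc1CNCCCNc1ccnc2cc(Cc3ccc(F)cc3Cl)ccc12` gives 2460 nM. Compound 2 `COc1ccc(F)cc1CNCCCNc1ccnc2cc(Cc3cccc(C(F)(F)F)c3)ccc12` gives 440 nM, the lowest of the two numbers, after a step of a 5.6-fold lower number from compound 1 to compound 2 (0.75 log units; beyond the scatter). Compound 3 `COc1ccc(F)cc1CNCCCNc1ccnc2cc(-c3ccc(C(F)(F)F)cc3)ccc12` differs from compound 2 by 4-(trifluoromethyl)phenyl in place of 3-(trifluoromethyl)benzyl on an aromatic carbon. Among the compounds with values here, no measured step matches this change: the one step seen, from compound 1 to compound 2, exchanged one ring for another while keeping the saturated chain carbon, and it moved the number by a modest amount. Within the data shown here, the change to compound 3 removes that chain carbon and moves the trifluoromethyl group, so the one step seen is only a loose guide to how far the number may move. The step from compound 2 to compound 3 is expected to be a 1.6-fold higher number from compound 2 to compound 3 (0.20 log units; within the scatter), leaning toward a modestly higher number. Compound 3 is estimated at 700 nM, within 180 nM to 2800 nM.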

Compound 3, half-maximal effective concentration: 5190 nM
Compound 3: middle estimate off by 7.4-fold (0.87 log units), on the low side; measured number above the stated range.
By their numbers in this assay, from the lowest: compound 2; then compound 1; then compound 3.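

In this assay this position on the shared core proves sensitive to the link as well as to the ring: 4-(trifluoromethyl)phenyl in place of 3-(trifluoromethyl)benzyl gives a 12-fold higher number from compound 2 to compound 3 (1.07 log units; beyond the scatter) and so a larger move than the earlier ring exchange, which kept the saturated chain carbon and gave a 5.6-fold lower number from compound 1 to compound 2 (0.75 log units; beyond the scatter) in the opposite direction. Against 2-chloro-4-fluorobenzyl the same replacement gives a 2.1-fold higher number from compound 1 to compound 3 (0.32 log units; beyond the scatter) and leaves compound 3, the one compound here without that chain carbon, with the highest number of the three. Nothing measured here accounts for this rise.

The step to compound 3 removes the chain carbon and also moves the trifluoromethyl group, and the compounds shown cannot separate these two changes. As far as these compounds go, a 3-(trifluoromethyl)phenyl group or a 4-(trifluoromethyl)benzyl group at this position would be the direct test, and how either would read remains open.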